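Series notes: hydrogen in place of methyl on an aromatic oxygen

A few compounds are considered here, and "the series" means these few. Any claim that something is new, unique, unknown or untested is made for them only; others in the source may bear on it.

Measured so far:
compound 1, `COc1cc(N2C(N)=C(C#N)C(c3c(O)ccc4ccccc34)C3=C2CC(C)(C)CC3=O)cc(OC)c1OC`, 15%
compound 2, `COc1ccccc1C1C(C#N)=C(N)N(c2cc(OC)c(OC)c(OC)c2)C2=C1C(=O)CC(C)(C)C2`, 70%

Among the compounds with values here, in a functional assay on Ehrlich cells (Mus musculus) for cytotoxicity, tested at 50 ug/mL (on this read-out higher numbers stand for a stronger effect at the one concentration tested and lower numbers for a weaker effect), compound 2 gives 70%, the highest of the two numbers so far; its nearest neighbour is compound 1 at 15%, and the single measured step, a number 55 percentage points higher from compound 1 to compound 2 (beyond the scatter), lies beyond the scatter. Compound 3, `COc1cc(N2C(N)=C(C#N)C(c3ccccc3O)C3=C2CC(C)(C)CC3=O)cc(OC)c1OC`, is not yet measured. It differs from compound 2 as follows: hydrogen in place of methyl on an oxygen on an aromatic ring. Within the data shown here, only one step is known, and it does not isolate this change: between compound 1 and compound 2 the hydroxy group and the naphthalene ring are exchanged together, so the measured rise cannot be split between the two parts. Among the measured compounds shown here, compound 1, which carries a hydroxy group, gives the lower of the two numbers, and that is the only hint bearing on compound 3. Compound 3 is therefore expected to land between the two measured numbers, a step of a number 20 percentage points lower from compound 2 to compound 3 (beyond the scatter), with wide uncertainty. The estimate for compound 3 is 50%, range 20% to 75%.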

Compound 3, a percentage reported as activity, at one concentration (the size of the read-out at that concentration, not a potency): 2%
Estimate against measurement, compound 3: 48 percentage points above; the whole stated range lies above it.
By their numbers in this assay, from the lowest: compound 3; then compound 1; then compound 2.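

In this assay, the methoxy to hydroxy change on the aromatic ring now stands alone and gives a number 68 percentage points lower from compound 2 to compound 3 (beyond the scatter) as a large step, so removing this methyl is enough to lose most of the read-out, without any change to the rest of the molecule. With the hydroxy group held in place, 2-hydroxyphenyl in place of 2-hydroxynaphthalen-1-yl gives a number 13 percentage points lower from compound 1 to compound 3 (beyond the scatter) as a modest step, which shows that the naphthalene was not what held compound 1 low and that most of the earlier rise goes with the methoxy group instead. Across these three compounds, both hydroxy compounds sit low and the single methoxy compound sits high, and none of the three goes against this pattern.

Nothing measured here bears on why the methyl on this oxygen matters so much. Going by these compounds, it remains open whether the read-out depends on methyl specifically or would hold with a larger group on the same oxygen, such as ethyl or acetyl, and whether a methoxy group on the naphthalene would restore the read-out of compound 1.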